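The source may hold more compounds than are shown below. What is called first, only, known or untested is meant among the compounds shown, and "the series" means these compounds.

Measured compounds:
Compound 1: `COc1cc(C)c(/C=C/C(C)=C/C=C(F)/C(C)=C/C(=O)O)c(C)c1C`, 80%
Compound 2: `COc1cc(C)c(/C=C/C(C)=C(F)/C=C/C(C)=C/C(=O)O)c(C)c1C`, 54%

In a functional assay on the whole organism (strain Hart Swiss) with Mus musculus as the target, with stated times of 5 days and 2 weeks, at a dose of 10 mg/kg by the intraperitoneal route (a higher number here means a stronger effect of the compound at the dose given, a lower number a weaker effect), compound 1 gives 80%, while compound 2 gives 54% in this assay. Within the data shown here, of the two numbers known, compound 2 stands lowest; the nearest is compound 1, which lies a distance above it that is beyond the scatter of repeated measurements.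

Compound 3, `COC(=O)/C=C(C)/C=C/C(F)=C(C)/C=C/c1c(C)cc(OC)c(C)c1C`, has not yet been measured in this assay. It differs from compound 2 in one place:
methyl in place of hydrogen on an oxygen next to a carbonyl group

Among the measured compounds shown here, no pair of measured compounds shows this same change, so the two values at hand say nothing directly about its size or direction. The account therefore rests on the change itself and on the standing of compound 2 alone. The author expects a step that is either downward and of modest size or none beyond the scatter, with a downward lean, written as a number 9 percentage points lower from compound 2 to compound 3 (within the scatter). For compound 3 the activity in this assay is estimated at 45%, with a range expected from 20% to 75%.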

Compound 3, a percentage reported as activity, at one dose (the size of the read-out at that dose, not a potency): 35%
Compound 3: the middle estimate sits 10 percentage points above what was measured, and the stated range covers the measured number.
By their numbers in this assay, from the lowest: compound 3; then compound 2; then compound 1.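

In this assay, among these compounds, the step on replacing the carboxy group with methoxycarbonyl is a number 19 percentage points lower from compound 2 to compound 3 (beyond the scatter), the first reading of any change at this position. It shows that capping the oxygen next to the carbonyl group with a methyl does not remove the effect at the dose given, since compound 3 still gives 35%, yet the free carboxy form holds the higher number of this pair. Nothing measured here accounts for the step.

On these data alone, this is a single pair, so neither the size nor the direction of the change can be taken as general, and whether it would carry over to the core of compound 1 stays open. As far as these compounds go, it is also open how other replacements at this place, such as an ethoxycarbonyl group, a longer-chain ester or a primary amide, would stand against the carboxy group of compound 2 and the methoxycarbonyl group of compound 3.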